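Catechol benzamides: acetamido in place of the sulfonamide

The compounds below may be only part of what the source reports. "The series", "measured", "known", "first", "only" and "open" are said of these compounds alone.

Measured so far in an ADME assay on NCI-H630 cells (Homo sapiens) for cytotoxicity, read by MTT assay, with a stated time of 72 h; a lower number here means that less compound is tolerated, a higher number that more compound is tolerated:
compound 1 `O=C(NCc1ccc(F)cc1)c1cccc(O)c1O` — compound 1 gives > 40000 nM, a limit of the assay.
compound 2 `O=C(NCc1ccc(F)cc1)c1cc(S(=O)(=O)N2CCCCC2)cc(O)c1O` — compound 2 gives 13000 nM.
compound 3 `CC(C)(C)NS(=O)(=O)c1cc(O)c(O)c(C(=O)NCc2ccc(F)cc2)c1` — compound 3 gives > 10000 nM, a limit of the assay.

Compound 3 therefore has no number of its own in this assay, only a limit (the limit of > 10000 nM in this assay, at which 1 of the 3 values shown sits). Compound 1 likewise sits at a limit (the limit of > 40000 nM in this assay, at which 1 of the 3 values shown sits). Among the compounds with values here, compound 2 is the only member with a read number. Within the data shown here, of the steps, an at least 3.0-fold lower number from compound 1 to compound 2 (0.48 log units; beyond the scatter) is the one readable change. The step that the two limits leave unreadable from compound 1 to compound 3 cannot be sized, and the step that the limit leaves unreadable from compound 2 to compound 3 cannot be sized either.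

Compound 4 `CC(=O)Nc1cc(O)c(O)c(C(=O)NCc2ccc(F)cc2)c1` differs from compound 3 by acetamido in place of (tert-butyl)sulfamoyl on an aromatic carbon. Among the measured compounds shown here, no measured step swaps a sulfonyl-bearing group for an acetamido group, and both steps that touch compound 3 are unreadable, so the step that the limit leaves unreadable from compound 3 to compound 4 is only an expectation that nothing beyond the scatter emerges, most likely another limit. Compound 4 is expected to give about 25000 nM in this assay, within 8000 nM to 80000 nM.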

Compound 4, half-maximal cytotoxic concentration: < 10000 nM
Compound 4: a limit, no number (the forecaster's own chance of this, stated with the estimate: 65%); middle value at least 2.5-fold (0.39 log units) away from the limit.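

In this assay compound 4 gives < 10000 nM, a limit and not a number, and the only limit on this side among the compounds shown: the limit of < 10000 nM in this assay, at which 1 of the 4 values shown sits.

Placing acetamido instead of hydrogen on this aromatic carbon, para to a hydroxy group, gives an at least 4.0-fold lower number from compound 1 to compound 4 (0.60 log units; beyond the scatter), so the drop seen with (piperidin-1-yl)sulfonyl, an at least 3.0-fold lower number from compound 1 to compound 2 (0.48 log units; beyond the scatter), is not confined to a sulfonyl-bearing group, although compound 3 can neither support nor contradict this pattern. Against the sulfonyl compound with a read number, the change gives an at least 1.3-fold lower number from compound 2 to compound 4 (0.11 log units; that floor lies within the scatter), and since that floor lies within the scatter, no order between the two can be stated. Acetamido in place of (tert-butyl)sulfamoyl gives a number no higher from compound 3 to compound 4 (the limit leaves the size open), and the size of this step and of the other steps that touch compound 3 cannot be read.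

Going by these compounds, how far compound 4 really lies from compound 2 stays open, as does whether compound 3 belongs with them or with compound 1. Also open, on these data alone, is where a free amine or a carboxylic acid on this carbon, or a longer chain in place of the acetyl methyl, would fall in this assay.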